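Swapping a Butyl Chain for an Oxetane Ring

This account rests on a few compounds, and the source may have more. Where it says the series, first, only, none or still open, it means among the compounds named here.

Compound 1, `CCCCn1nc(C(=O)N[C@H]2COc3ccccc3N(C)C2=S)nc1Cc1ccccc1`: in a toxicity assay on HT-29 cells (Homo sapiens) for cytotoxicity (a higher number here means that more compound is tolerated, a lower number that less compound is tolerated), compound 1 gives > 100000 nM, which is a limit of the assay.
Compound 2, `CC(C)Cn1nc(C(=O)N[C@H]2COc3ccccc3N(C)C2=S)nc1Cc1ccccc1`: compound 2 gives > 100000 nM, again a limit.
Compound 3, `CN1C(=S)[C@@H](NC(=O)c2nc(Cc3ccccc3)n(CCC(F)(F)F)n2)COc2ccccc21`: compound 3 gives > 100000 nM, also a limit.

Compound 1 thus stands at the limit, and the two further values shown are limits as well. The step that the two limits leave unreadable from compound 1 to compound 2, the step that the two limits leave unreadable from compound 1 to compound 3 and the step that the two limits leave unreadable from compound 2 to compound 3 all stay unreadable because of the limit of > 100000 nM in this assay, at which 3 of the 3 values shown sit. None of the three compounds can be told apart from the others by these numbers.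

Compound 4, `CN1C(=S)[C@@H](NC(=O)c2nc(Cc3ccccc3)n(C3COC3)n2)COc2ccccc21`, differs from compound 1 by oxetan-3-yl in place of butyl on an aromatic nitrogen. All three measured steps alter the group carried on that same aromatic nitrogen, so all three bear on this change, yet not one of them has a readable size. Nothing in them points to a shift in this assay beyond the scatter, in either direction. Compound 4 is therefore expected to sit at the limit as well, and the step of a number no higher from compound 1 to compound 4 (the limit leaves the size open) is estimated to be negligible. The estimate for compound 4 is 100000 nM, with a range from 40000 nM to 250000 nM.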

Compound 4, half-maximal cytotoxic concentration: > 100000 nM
Compound 4: a limit, no number (the forecaster's own chance of this, stated with the estimate: 85%); the middle value lies on the limit itself.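

The result for compound 4 is also a limit, so its steps from compound 1, compound 2 and compound 3 cannot be read, because every value shown stands at the same limit: the limit of > 100000 nM in this assay, at which 4 of the 4 values shown sit.

The compounds shown leave open whether any of these groups on the aromatic nitrogen changes how much compound is tolerated in this assay, and by how much.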